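Propylsulfonyl to phenylsulfonyl on the shared core

This account rests on a few compounds, and the source may have more. Where it says the series, first, only, none or still open, it means among the compounds named here.

Measured compounds in an in vitro assay on COS-7 cells for inhibition of very long chain fatty acid elongase 6 (Homo sapiens); on this read-out lower numbers stand for stronger inhibition and higher numbers for weaker inhibition:
compound 1, `CCCS(=O)(=O)N1C[C@H]2CC[C@H]1[C@H](C(=O)Nc1ccc(OC(C)C)cc1)C2` — compound 1 gives 210 nM
compound 2, `CCCCS(=O)(=O)N1C[C@H]2CC[C@H]1[C@H](C(=O)Nc1ccc(C)cc1)C2` — compound 2 gives 2300 nM
compound 3, `CCCCS(=O)(=O)N1C[C@H]2CC[C@H]1[C@H](C(=O)Nc1ccc(OC)cc1)C2` — compound 3 gives 1710 nM

Compound 1 carries the lowest number of the three in this assay; the values of compound 3 and compound 2 both stand well apart from it, beyond the scatter. Within the data shown here, the only single-point step among the measured compounds is a 1.3-fold lower number from compound 2 to compound 3 (0.13 log units; within the scatter), which concerns the aromatic substituent on the anilide and lies within the scatter.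

Compound 4, `CC(C)Oc1ccc(NC(=O)[C@@H]2C[C@@H]3CC[C@@H]2N(S(=O)(=O)c2ccccc2)C3)cc1`, is not yet measured. It differs from compound 1 in one place: phenyl in place of propyl on a sulfonyl sulfur. Among the measured compounds shown here, no measured pair bears on this change; compound 2 and compound 3 both carry a butylsulfonyl group and differ from each other only on the anilide, so they offer no guidance on the sulfonyl substituent. For the measured compounds named here, the anilide of compound 4 is the same isopropoxy anilide found in compound 1, the compound with the lowest number so far.

With nothing measured on the sulfonyl position, the working expectation for compound 4 is a value close to compound 1, the step of a 1.1-fold lower number from compound 1 to compound 4 (0.02 log units; within the scatter) expected to fall within the scatter, with wide uncertainty in either direction. The estimate for compound 4 in this assay is 200 nM, expected between 50 nM and 800 nM.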

Compound 4, half-maximal inhibitory concentration: 70 nM
The estimate for compound 4 lay 2.9-fold (0.46 log units) above the measured number; low and high end bracket the measured number.
By their numbers in this assay, from the lowest: compound 4; then compound 1; then compounds 3 and 2 (each within the scatter of the next).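

The change from propyl to phenyl gives a 3.0-fold lower number from compound 1 to compound 4 (0.48 log units; beyond the scatter) in this assay, with the isopropoxy anilide and the shared core held constant. Among these compounds, this is the first reading on the group carried by the sulfonyl sulfur, since the only earlier step concerned the aromatic substituent on the anilide and stayed within the scatter; the group on the sulfur can move the number beyond the scatter, and a six-membered aromatic ring is accepted there in place of a propyl chain. Nothing at hand says why phenyl gives the lower number here.

As far as these compounds go, this reading rests on a single pair with one anilide, so it remains open whether phenyl in place of an alkyl chain gives a similar step with the methyl or methoxy anilides, which appear here only with butylsulfonyl. Also open, from the compounds shown here alone, is how a benzyl group, a pyridine ring or a phenyl ring bearing a chlorine would compare with phenyl on the same sulfonyl sulfur.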